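This account rests on a few compounds, and the source may have more. Where it says the series, first, only, none or still open, it means among the compounds named here.

Measured in a functional assay on A549 cells (Homo sapiens) for antiproliferative activity, read by MTT assay, with a stated time of 72 h; on this read-out higher numbers stand for weaker inhibition and lower numbers for stronger inhibition:
- Compound 1 `COc1cc(-n2ncnc2-c2ccc(OC(F)(F)F)cc2)cc(OC)c1OC`: > 10000 nM (a limit)
- Compound 2 `COc1cc(-n2ncnc2-c2ccc(Cl)c(Cl)c2)cc(OC)c1OC`: > 10000 nM (a limit)

Compound 2 stands at > 10000 nM in this assay, which is a limit of the assay and not a number. Both measured compounds sit at the same place, (the limit of > 10000 nM in this assay, at which 2 of the 2 values shown sit).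

Compound 3 `COc1cc(-n2ncnc2-c2ccccc2)cc(OC)c1OC` has not yet been measured. It differs from compound 2 in one place: phenyl in place of 3,4-dichlorophenyl on an aromatic carbon of a five-membered aromatic ring with 3 nitrogen (phenyl in place of 3,4-dichlorophenyl on an aromatic carbon).

Within the data shown here, no measured pair shows what this change does. With compound 1 and compound 2 both at the limit of > 10000 nM in this assay, at which 2 of the 2 values shown sit, no step beyond the scatter is expected in this assay, in either direction. The expected size of the change is a number no higher from compound 2 to compound 3 (the limit leaves the size open), an estimate resting on little. The estimate for compound 3 is 10000 nM, with an expected range of 3000 nM to 30000 nM.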

Compound 3, half-maximal inhibitory concentration: > 10000 nM
Compound 3: a limit, no number; the forecaster's own chance of this, stated with the estimate: 75%; the middle value sits exactly at the limit.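

No step can be read from compound 3 to compound 2 or to compound 1, because all three sit at one place: the limit of > 10000 nM in this assay, at which 3 of the 3 values shown sit. The compounds shown leave open whether phenyl and 3,4-dichlorophenyl differ at all in this assay, and in which direction.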